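Methyl on the chain: a second look at one change

A few compounds are considered here, and "the series" means these few. Any claim that something is new, unique, unknown or untested is made for them only; others in the source may bear on it.

Compound 1 `C/N=C(\S)CCn1nc(-c2ccccc2)ccc1=O` gives 68.2% in a functional assay on the whole organism (stomach) for inhibition, with Rattus norvegicus as the target, at a dose of 100 mg/kg by the intraduodenal route; on this read-out higher numbers stand for more inhibition at the one dose given (going by the name of the read-out) and lower numbers for less inhibition. Compound 2 `CC/N=C(\S)CCn1nc(-c2ccccc2)ccc1=O` gives 50.3% in this assay; the step of a number 17.9 percentage points lower from compound 1 to compound 2 (beyond the scatter) goes with the change (methyl in place of hydrogen on a saturated chain carbon bound to a double-bonded nitrogen). Compound 3 `N=C(S)CCn1ncccc1=O` gives 28.8% in this assay, the lowest of the three numbers; the difference between the core of compound 3 and the core of compound 1 is not broken down here, so the two values are only set side by side. Compound 4 `CC(CC(=N)S)n1ncccc1=O` is not yet measured; from compound 3 it differs by methyl in place of hydrogen on a saturated chain carbon bound to an aromatic nitrogen and a saturated chain carbon. Going by the values given here, this is the same kind of change as the one from compound 1 to compound 2, but not the same: there the methyl entered on a saturated chain carbon bound to a double-bonded nitrogen, here it enters on a saturated chain carbon bound to an aromatic nitrogen and a saturated chain carbon. Among the compounds with values here, with only one earlier instance, on a different place and a different core, the expected step of a number 8.8 percentage points lower from compound 3 to compound 4 (within the scatter) is set smaller than the earlier one, because the starting point of compound 3 at 28.8% already leaves little room to fall. Compound 4 is estimated at 20%, between 5% and 40%.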

Compound 4, a percentage reported as inhibition, in the whole organism at one dose (the size of the read-out at that dose, not a potency): 38.8%
Estimate against measurement, compound 4: 18.8 percentage points below; low and high end bracket the measured number.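

In this assay the methyl step on the core of compound 3 reads a number 10 percentage points higher from compound 3 to compound 4 (within the scatter), which gives no clear effect of the methyl on that core. Set beside the earlier step, methyl in place of hydrogen does not carry over as one fixed step in this series: the same change on two cores in this assay, a number 17.9 percentage points lower (beyond the scatter) from compound 1 to compound 2 and a number 10 percentage points higher (within the scatter) from compound 3 to compound 4, 27.9 percentage points apart, beyond the scatter of two such steps. This does not show that the core alone separates the two steps: the two pairs also differ in the place of the methyl, and with one pair per core no rule for a further core can be drawn.

The compounds shown leave open what a methyl on a saturated chain carbon bound to an aromatic nitrogen and a saturated chain carbon would do on the core of compound 1, which would separate place from core. They also leave open whether a longer chain such as ethyl, or a carboxylic acid, at that place would give a step beyond the scatter.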